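A few compounds are considered here, and "the series" means these few. Any claim that something is new, unique, unknown or untested is made for them only; others in the source may bear on it.

Measured compounds in a functional assay on HeLa cells (Homo sapiens) for cytotoxicity, read by MTT assay, with a stated time of 48 h; on this read-out higher numbers stand for weaker inhibition and lower numbers for stronger inhibition:
compound 1 `O=C(O[C@H]1C[C@H](n2cc(F)c(=O)[nH]c2=O)O[C@@H]1COP(=O)(O)Oc1ccccc1)c1ccccc1` — 5860 nM
compound 2 `CCCCCCCCCc1ccc(OP(=O)(O)OC[C@H]2O[C@@H](n3cc(F)c(=O)[nH]c3=O)C[C@@H]2OC(=O)c2ccccc2)cc1` — 40100 nM

Going by the values given here, compound 1 gives the lowest number of the two measured compounds in this assay; compound 2 stands apart from it by a 6.8-fold higher number from compound 1 to compound 2 (0.84 log units; beyond the scatter), a step that goes beyond the scatter, and it is the only measured step in the set. That step concerns nonyl in place of hydrogen on an aromatic carbon and touches a different part of the shared core.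

Compound 3 `O=C(O[C@H]1C[C@H](n2cc(F)c(=O)[nH]c2=O)O[C@@H]1COP(=O)(O)Oc1cccnc1)c1ccccc1` differs from compound 1 by pyridin-3-yl in place of phenyl on an oxygen. Among the compounds with values here, no measured pair shows this exchange, so the step from compound 1 to compound 2 offers no direct guide; it only shows that a change at the aryl group attached to the oxygen on phosphorus can move the number in this assay. Replacing phenyl with pyridin-3-yl is a smaller alteration than adding nonyl, and the two groups keep the same ring size.

The number for compound 3 is therefore expected to stay close to that of compound 1, with a step of a 1.1-fold higher number from compound 1 to compound 3 (0.05 log units; within the scatter) that is not expected to exceed the scatter. Compound 3 is estimated at 6500 nM, within 2500 nM to 17000 nM.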

Compound 3, half-maximal inhibitory concentration: 6900 nM
Beside the measured number, compound 3's estimate is 1.1-fold (0.03 log units) below it, within the range that was stated.
By their numbers in this assay, from the lowest: compounds 1 and 3 (each within the scatter of the next); then compound 2.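

In this assay the exchange of phenyl for pyridin-3-yl, on an oxygen whose other neighbour is phosphorus, gives a 1.2-fold higher number from compound 1 to compound 3 (0.07 log units; within the scatter) and so leaves compound 1 and compound 3 within the scatter of each other. Until now this aryl group was known only through the nonyl step, which gave a 6.8-fold higher number from compound 1 to compound 2 (0.84 log units; beyond the scatter) on the same read-out; the new pair shows that a change here need not move the number, since a ring nitrogen and a hydrogen-bond acceptor enter with no step beyond the scatter. No measurement at hand accounts for either step, so both stand as observations only.

Still open, from the compounds shown here alone, is how pyridin-2-yl or pyridin-4-yl would read in the same place, and whether an amine or a carboxylic acid carried on the pyridin-3-yl ring would leave the number as flat. Also open, going by these compounds, is whether a shorter chain such as methyl or butyl, put where compound 2 carries nonyl, would give a step of smaller size or one within the scatter.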